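Cyanomethyl pyrazole series: cytotoxicity at a single low concentration

The compounds below may be only part of what the source reports. "The series", "measured", "known", "first", "only" and "open" are said of these compounds alone.

Measured compounds:
compound 1 `COc1cc(C)cc(-c2nn(CC#N)cc2-c2ccc(-c3cccc(C(C)=O)c3)nc2)c1` gives 93%
compound 2 `Cc1cc(O)cc(-c2nn(CC#N)cc2-c2ccnc(-c3ccc(Oc4ccccc4)cc3)c2)c1` gives 100%
compound 3 `COc1cc(C)cc(-c2nn(CC#N)cc2-c2ccnc(-c3ccc(N(C)C)cc3)c2)c1` gives 110%

In a functional assay on RPMI8266 cells (Homo sapiens) for cytotoxicity, read by sulforhodamine B assay, with a stated time of 48 h, tested at 0.01 uM (on this read-out higher numbers stand for a weaker effect at the one concentration tested and lower numbers for a stronger effect), compound 3 holds the highest of the three numbers. Its nearest neighbour is compound 2, whose number sits lower but within the usual scatter, so no order between the two can be read. Compound 1 sits further down, beyond the scatter, so compound 1 shows a somewhat stronger effect at this concentration than compound 3. All three numbers sit close to no effect at all.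

Compound 4 `Cc1cc(O)cc(-c2nn(CC#N)cc2-c2ccnc(-c3ccc(N(C)C)cc3)c2)c1` has not yet been measured. It differs from compound 3 in one place: hydrogen in place of methyl on an oxygen on an aromatic ring. Among the measured compounds shown here, no pair of measured compounds differs in just this way, so the size of this step has no direct precedent here. Compound 2, which carries the hydroxy, gives 100% and sits within the scatter of compound 3, which gives 110%.

The step from compound 3 to compound 4 in this assay is expected to be a number 9 percentage points lower from compound 3 to compound 4 (within the scatter), a small move that stays within the scatter. Compound 4 is therefore estimated at 101%, with a range from 88% to 114%.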

Compound 4, a percentage reported as activity, at one concentration (the size of the read-out at that concentration, not a potency): 99%
The estimate for compound 4 lay 2 percentage points above the measured number; the range from low to high includes it.
By their numbers in this assay, from the lowest: compounds 1, 4, 2 and 3 (each within the scatter of the next, the first and the last beyond it).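

In this assay, methoxy to hydroxy on the 3-methoxy-5-methylphenyl gives a number 11 percentage points lower from compound 3 to compound 4 (beyond the scatter), the first measured size for this change at this position, and a modest one. Dimethylamino in place of phenoxy on an aromatic carbon gives a number 1 percentage points lower from compound 2 to compound 4 (within the scatter), so with the hydroxy present this exchange shows no readable change, and compound 4 at 99% remains close to no effect at all. No measured evidence bears on the origin of either step.

On these data alone, whether the methoxy to hydroxy step keeps its size with a group other than dimethylamino on the far aryl ring remains open, as does the outcome with an ethoxy or an amine in place of the hydroxy. A single low concentration also leaves the behaviour of these compounds at higher concentrations unknown.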